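Chloro for hydrogen on the terminal phenyl of the urea

A few compounds are considered here, and "the series" means these few. Any claim that something is new, unique, unknown or untested is made for them only; others in the source may bear on it.

Measured so far:
compound 1 `O=C(Nc1cccc(CNc2ncnc3ccccc23)c1)Nc1ccccc1F`, 17500 nM
compound 2 `COc1cc2ncnc(NCc3cccc(NC(=O)Nc4ccccc4)c3)c2cc1OC`, 19700 nM

In a functional assay on HepG2 cells (Homo sapiens) for antiproliferative activity, read by MTT assay (on this read-out lower numbers stand for stronger inhibition and higher numbers for weaker inhibition), compound 2 gives 19700 nM, the higher of the two numbers shown, while compound 1 gives 17500 nM; the two values lie within the scatter of each other, so no order between them can be read. Compound 3 `COc1cc2ncnc(NCc3cccc(NC(=O)Nc4ccc(Cl)cc4)c3)c2cc1OC` differs from compound 2 by a single change, (chloro in place of hydrogen on an aromatic carbon), on an aromatic carbon of a six-membered aromatic ring of carbon only, para to a large group. Among the compounds with values here, no measured pair shows this change, so its effect in this assay is unknown from the present data. A step of about the scatter, leaning toward a lower number, is expected, namely a 1.6-fold lower number from compound 2 to compound 3 (0.22 log units; within the scatter). Compound 3 is estimated at 12000 nM, in the range 5000 nM to 30000 nM.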

Compound 3, half-maximal inhibitory concentration: > 50000 nM
Compound 3 was reported as a limit (the forecaster's own chance of this, stated with the estimate: 10%); middle value at least 4.1-fold (0.61 log units) away from the limit.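

Within the data shown here, neither earlier compound carries a group at this place on the terminal phenyl, so this is the first reading of it. In this assay, chloro in place of hydrogen gives an at least 2.5-fold higher number from compound 2 to compound 3 (0.40 log units; beyond the scatter), which means that this single added heavy atom weakens inhibition in this series. Compound 3 stands only as a limit: the limit of > 50000 nM in this assay, at which 1 of the 3 values shown sits.

From the compounds shown here alone, whether this belongs to chloro itself or to any group at this place stays open. A methoxy group or an amine at the same place would separate the two readings.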